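A Methyl Added to the Core of Compound 2

A few compounds are considered here, and "the series" means these few. Any claim that something is new, unique, unknown or untested is made for them only; others in the source may bear on it.

Compound 2 `N#C/C(=C\C=C(/Cl)c1ccc(Br)cc1)C(=O)c1c[nH]c2ccccc12` gives 76.7% in a functional assay for inhibition, read by Griess assay, with a stated time of 150 min, tested at 1 mM (on this read-out higher numbers stand for more inhibition at the one concentration tested (going by the name of the read-out) and lower numbers for less inhibition), the higher of the two numbers recorded, while compound 1 `COc1ccc(/C(Cl)=C/C=C(\C#N)C(=O)c2c(C)[nH]c3ccccc23)cc1` gives 74% in this assay, a value within the scatter of compound 2. Compound 3 `Cc1[nH]c2ccccc2c1C(=O)/C(C#N)=C/C=C(\Cl)c1ccc(Br)cc1` is compound 2 with a single change: methyl in place of hydrogen on an aromatic carbon. Going by the values given here, no step between measured compounds carries this change, so its size is not known from the data; compound 1 already bears the methyl on its core and sits within the scatter of compound 2. Compound 3 is therefore expected to give 75% in this assay, within 62% to 86%. The expected step of a number 1.7 percentage points lower from compound 2 to compound 3 (within the scatter) is estimated to be none beyond the scatter.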

Compound 3, a percentage reported as inhibition, at one concentration (the size of the read-out at that concentration, not a potency): 78.3%
Beside the measured number, compound 3's estimate is 3.3 percentage points below it, within the range that was stated.
By their numbers in this assay, from the lowest: compounds 1, 2 and 3 (each within the scatter of the next).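

In this assay the methyl in place of hydrogen on this aromatic carbon now has a measured step, a number 1.6 percentage points higher from compound 2 to compound 3 (within the scatter) and so the change leaves the read-out unmoved beyond the scatter. With the methyl present on the core, bromo in place of methoxy on an aromatic carbon can also be read, as a number 4.3 percentage points higher from compound 1 to compound 3 (within the scatter) and this step too stays inside the scatter. Nothing measured here explains either step.
On these data alone, whether a group larger than methyl at this position, such as an ethyl chain, would shift the number remains open. So does the effect of a carboxylic acid or an amine there.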